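Furan-2-yl for pyrimidin-5-yl on the shared core

The source may report more compounds than this note shows. Statements on the series, on what has been measured and on what is new or still open speak of the compounds shown alone.

Two compounds in the series have a reading in a physicochemical assay for solubility, in phosphate buffer, at pH 6.8; a lower number here means a less soluble compound, a higher number a more soluble compound. Compound 1 (`CCn1c(NC(C)C)nc2c(C3CCN(C(=O)c4ccccc4)C3)csc2c1=O`) gives 21 ug/mL, and compound 2 (`CCn1c(NC(C)C)nc2c(-c3cncnc3)csc2c1=O`) gives 18 ug/mL. Compound 2 therefore stands level with compound 1, within the scatter of the measurement. Among the measured compounds shown here, the data hold no measured step to serve as a precedent for the next change.

Compound 3 (`CCn1c(NC(C)C)nc2c(-c3ccco3)csc2c1=O`) carries furan-2-yl in place of pyrimidin-5-yl on an aromatic carbon of the shared core: furan-2-yl in place of pyrimidin-5-yl on an aromatic carbon. A moderate downward step in this assay is expected, slightly beyond the scatter, although this direction has no measured support in the series. The estimated change is a 2.3-fold lower number from compound 2 to compound 3 (0.35 log units; beyond the scatter). With compound 2 at 18 ug/mL as the only close reference, the expected range stays wide. For compound 3 the estimate is 8 ug/mL, with an expected range of 3 ug/mL to 20 ug/mL.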

Compound 3, solubility: 0.1 ug/mL
Compound 3: middle estimate off by 80-fold (1.90 log units), on the high side; measured number outside the range, below it.
By their numbers in this assay, from the lowest: compound 3; then compounds 2 and 1 (each within the scatter of the next).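

Among the compounds shown here, on an aromatic carbon two ring bonds from the ring sulfur, furan-2-yl in place of pyrimidin-5-yl gives the first measured step in this assay for this series, and it is large: a 180-fold lower number from compound 2 to compound 3 (2.26 log units; beyond the scatter). The readings of compound 1 and compound 2 stand within the scatter of each other and gave no sign that this position could move the read-out so far; compound 3 shows that a single change of group here can do so. No measurement in hand bears on the cause of this step.

The change replaces a six-membered aromatic ring with 2 hetero atoms by a five-membered aromatic ring with 1 hetero atom, so ring size and hetero atoms remain unseparated. Phenyl, pyridin-3-yl or thiophen-2-yl at this carbon would help separate them.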